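A few compounds are considered here, and "the series" means these few. Any claim that something is new, unique, unknown or untested is made for them only; others in the source may bear on it.

Compound 1 `CCc1ccc2c(c1)N(C1=CCCC1=O)CC(C)(C)S2`, compound 2 `CC(=O)c1ccc2c(c1)N(C1=CCCC1=O)CC(C)(C)S2` and compound 3 `CC1(C)CN(C2=CCCC2=O)c2cc(N)ccc2S1` share one core and differ only in the group on an aromatic carbon. In a functional assay on aorta (Rattus norvegicus, strain Wistar) (a higher number here means a larger maximal response, a lower number a smaller maximal response), compound 1 gives 97%, compound 2 gives 88% and compound 3 gives 96%. Compound 3 sits within the scatter of both other compounds, so none of the three numbers is separated from the others. Swapping the group at this carbon has moved little so far: a number 9 percentage points lower from compound 1 to compound 2 (within the scatter), a number 1 percentage points lower from compound 1 to compound 3 (within the scatter) and a number 8 percentage points higher from compound 2 to compound 3 (within the scatter). Compound 4 `CC1(C)CN(C2=CCCC2=O)c2ccccc2S1` differs from compound 3 by hydrogen in place of amino on an aromatic carbon. All three measured swaps at this carbon stayed within the scatter, which bears directly on this change. A step of a number 1 percentage points lower from compound 3 to compound 4 (within the scatter) is therefore expected, again within the scatter. Compound 4 is estimated at 95%, between 85% and 102%.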

Compound 4, largest response reached (Emax), in percent of the reference or control that the assay uses: 90%
For compound 4 the middle estimate is 5 percentage points above the measured one, and the stated range covers the measured number.
By their numbers in this assay, from the lowest: compounds 2, 4, 3 and 1 (each within the scatter of the next).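

Compound 4 has only hydrogen at this aromatic carbon, and even with no group there it does not separate from the others in this assay: the readings run a number 6 percentage points lower from compound 3 to compound 4 (within the scatter) and a number 2 percentage points higher from compound 2 to compound 4 (within the scatter) and a number 7 percentage points lower from compound 1 to compound 4 (within the scatter). Among these four compounds, therefore, ethyl, acetyl and amino show no separation from plain hydrogen at this carbon. No supporting data bear on these numbers.

As far as these compounds go, whether a carboxylic acid, a chlorine atom or a longer chain at this carbon would give a separated response remains open, as do changes elsewhere on the shared core.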